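The compounds below may be only part of what the source reports. "The series", "measured", "known", "first", "only" and "open" are said of these compounds alone.

Three measured compounds share one core: compound 1 `Cc1ccc(-c2[nH]c3ccccc3c2C2=C(Br)C(=O)C(Br)=C(c3c(C)[nH]c4ccccc34)C2=O)cc1`, compound 2 `Cc1[nH]c2ccccc2c1C1=C(Cl)C(=O)C(Cl)=C(c2c(-c3ccccc3)[nH]c3ccccc23)C1=O` and compound 3 `COc1ccc2[nH]c(C)c(C3=C(Cl)C(=O)C(Cl)=C(c4c(-c5ccc(C)cc5)[nH]c5ccccc45)C3=O)c2c1`. In a functional assay on MDA-MB-231 cells (Homo sapiens) for antiproliferative activity, read by CCK-8 assay, with a stated time of 48 h (a higher number here means a weaker inhibitor, a lower number a stronger inhibitor), compound 1 gives 5.89 ug/mL, compound 2 gives 5.27 ug/mL and compound 3 gives 6.04 ug/mL. Compound 3 lies within the usual scatter of both other compounds, so the three numbers cannot be separated. Compound 4 `Cc1ccc(-c2[nH]c3ccccc3c2C2=C(Cl)C(=O)C(Cl)=C(c3c(C)[nH]c4ccccc34)C2=O)cc1` differs from compound 3 by one change, hydrogen in place of methoxy on an aromatic carbon. For the measured compounds named here, no measured pair isolates this change, so the expected step from compound 3 to compound 4 in this assay, a 1.1-fold lower number from compound 3 to compound 4 (0.03 log units; within the scatter), is none beyond the scatter. The estimate for compound 4 is 5.6 ug/mL, with a range from 3 ug/mL to 10.5 ug/mL.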

Compound 4, half-maximal inhibitory concentration: 5.77 ug/mL
Compound 4: the middle estimate sits 1.0-fold (0.01 log units) below what was measured; measured number inside the range.
By their numbers in this assay, from the lowest: compounds 2, 4, 1 and 3 (each within the scatter of the next).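

Taking methoxy off the 5-methoxy-2-methyl-1H-indol-3-yl group and leaving hydrogen gives a 1.0-fold lower number from compound 3 to compound 4 (0.02 log units; within the scatter) in this assay, so at this position the two groups cannot be told apart. Methyl in place of hydrogen on an aromatic carbon gives a 1.1-fold higher number from compound 2 to compound 4 (0.04 log units; within the scatter), so that change cannot be separated from the scatter either. No other measurement bears on these results. On these data alone, whether an amine, a carboxylic acid or a longer chain at the methoxy position would shift the number stays open. Each change also rests on a single pair of compounds.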